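This account rests on a few compounds, and the source may have more. Where it says the series, first, only, none or still open, it means among the compounds named here.

Measured in a functional assay on microsomes for inhibition, with a stated time of 1 h; on this read-out lower numbers stand for stronger inhibition and higher numbers for weaker inhibition:
- compound 1 `CCOC(=O)c1cnn(-c2nc(-c3ccccc3F)c(C#N)c(=O)n2C)c1N`: 94 ug/mL
- compound 2 `CCOC(=O)c1cnn(-c2nc(-c3ccccc3O)c(C#N)c(=O)n2C)c1N`: 57 ug/mL

Among the compounds with values here, compound 2 has only compound 1 for comparison, and the one measured step, a 1.6-fold lower number from compound 1 to compound 2 (0.22 log units; within the scatter), does not separate the two. The next compound, compound 3 `CCOC(=O)c1cnn(-c2nc(-c3ccc(N(C)C)cc3)c(C#N)c(=O)n2C)c1N`, has 4-(dimethylamino)phenyl in place of 2-hydroxyphenyl on an aromatic carbon. Within the data shown here, no measured compound carries the entering group, so the data hold no direct precedent for it. Among the measured compounds shown here, the only guide is that same measured step, a 1.6-fold lower number from compound 1 to compound 2 (0.22 log units; within the scatter), which exchanged one substituent on the aromatic group now being replaced. That is thin evidence, and it points to no shift beyond the scatter in either direction. The expected change is a 1.2-fold higher number from compound 2 to compound 3 (0.09 log units; within the scatter). For compound 3 the estimated value in this assay is 70 ug/mL, with an expected range of 30 ug/mL to 160 ug/mL.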

Compound 3, half-maximal inhibitory concentration: 111 ug/mL
For compound 3 the middle estimate is 1.6-fold (0.20 log units) below the measured one, within the range that was stated.
By their numbers in this assay, from the lowest: compounds 2, 1 and 3 (each within the scatter of the next).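

In this assay the exchange of 2-hydroxyphenyl for 4-(dimethylamino)phenyl (at a 1.9-fold higher number from compound 2 to compound 3 (0.29 log units; within the scatter)) stays within the scatter, and so does the exchange of 2-fluorophenyl for the same group (at a 1.2-fold higher number from compound 1 to compound 3 (0.07 log units; within the scatter)). This position, on an aromatic carbon ortho to a cyano group, therefore now carries a larger entering group without a hydrogen-bond donor and with its substituent elsewhere on the phenyl, and none of the three compounds separates from the others in this read-out. Nothing measured here offers an explanation for these numbers.

Still open, from the compounds shown here alone, is whether a carboxylic acid or a primary amine on the phenyl, or a longer chain in place of the dimethylamino group, would move the number beyond the scatter. Also open, going by these compounds, is what a morpholine in place of the whole phenyl group would do.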